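From methoxy to ethoxy on the shared core

A few compounds are considered here, and "the series" means these few. Any claim that something is new, unique, unknown or untested is made for them only; others in the source may bear on it.

Compound 3 `COc1ccc(Nc2nccc(-c3sc(OC)nc3C)n2)c(OC)c1` carries a methoxy group where compound 1 `CNc1nc(C)c(-c2ccnc(Nc3ccc(OC)cc3OC)n2)s1` carries methylamino and compound 2 `COc1ccc(Nc2nccc(-c3sc(N(C)C)nc3C)n2)c(OC)c1` carries dimethylamino. In a functional assay on MV4-11 cells (Homo sapiens) for inhibition, read by resazurin assay, with a stated time of 72 h (on this read-out lower numbers stand for stronger inhibition of growth and higher numbers for weaker inhibition of growth), compound 3 gives 1400 nM, the highest of the three numbers; compound 1 gives 300 nM and compound 2 gives 170 nM, so that a 4.7-fold higher number from compound 1 to compound 3 (0.67 log units; beyond the scatter) and an 8.2-fold higher number from compound 2 to compound 3 (0.92 log units; beyond the scatter) lie beyond the scatter, whereas a 1.8-fold lower number from compound 1 to compound 2 (0.25 log units; within the scatter) does not. Compound 4 `CCOc1nc(C)c(-c2ccnc(Nc3ccc(OC)cc3OC)n2)s1` differs from compound 3 by methyl in place of hydrogen on a saturated chain carbon bound to an oxygen on an aromatic ring. For the measured compounds named here, no measured step touches this chain carbon; the closest comparison, a methyl entering elsewhere, is a 1.8-fold lower number from compound 1 to compound 2 (0.25 log units; within the scatter). Compound 4 is therefore expected to show a 1.2-fold lower number from compound 3 to compound 4 (0.07 log units; within the scatter), within the scatter. The estimate for compound 4 is 1200 nM, with a range from 500 nM to 3000 nM.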

Compound 4, concentration for 50% growth inhibition: 3890 nM
For compound 4 the middle estimate is 3.2-fold (0.51 log units) below the measured one; measured number outside the range, above it.
By their numbers in this assay, from the lowest: compounds 2 and 1 (each within the scatter of the next); then compound 3; then compound 4.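

In this assay, for the compounds shown here, the methoxy to ethoxy change is not silent: one added methyl on the saturated chain carbon bound to an oxygen gives a 2.8-fold higher number from compound 3 to compound 4 (0.44 log units; beyond the scatter), a step beyond the scatter at a place no earlier step had touched. Ethoxy also stands well apart from the amino groups, with a 23-fold higher number from compound 2 to compound 4 (1.36 log units; beyond the scatter) and a 13-fold higher number from compound 1 to compound 4 (1.11 log units; beyond the scatter), both large. Nothing measured here explains this change. Going by these compounds, whether a propyl ether would raise the number further remains open. So does whether an ethylamino group would keep the level of methylamino.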